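The source may report more compounds than this note shows. Statements on the series, on what has been measured and on what is new or still open speak of the compounds shown alone.

Measured compounds:
- compound 1, `O=C(Nc1cc(-c2ccccc2)nn1-c1ccccc1Br)c1ccccc1`: in an assay on HEK293 cells for displacement of a labelled ligand from metabotropic glutamate receptor 5 (Rattus norvegicus) (a lower number here means a stronger inhibitor, a higher number a weaker inhibitor), compound 1 gives 2600 nM
- compound 2, `O=C(Nc1cc(-c2ccccc2)nn1-c1ccccn1)c1ccccc1`: in this assay compound 2 gives > 10000 nM

Going by the values given here, compound 1 is the only compound here with an actual number in this assay. The other value shown is a limit. For compound 2 the result is > 10000 nM, which is a limit of this assay rather than a number; this is the limit of > 10000 nM in this assay, at which 1 of the 2 values shown sits. Among the compounds with values here, the one measured step is an at least 3.8-fold higher number from compound 1 to compound 2 (0.58 log units; beyond the scatter), and it concerns the aromatic ring carried on an aromatic nitrogen of the shared core.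

Compound 3, `N#Cc1cccc(C(=O)Nc2cc(-c3ccccc3)nn2-c2ccccc2Br)c1`, is not yet measured. It differs from compound 1 in a different place: cyano in place of hydrogen on an aromatic carbon, so that the benzoyl ring of the amide becomes a 3-cyanophenyl. Within the data shown here, no measured step touches this ring, so the step from compound 1 to compound 2 gives no direct guidance on it. With nothing to point either way, the change is expected to leave the number close to that of compound 1, with the step of a 1.2-fold lower number from compound 1 to compound 3 (0.07 log units; within the scatter) expected to stay within the scatter. The estimate for compound 3 in this assay is therefore 2200 nM, expected to lie between 600 nM and 8000 nM.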

Compound 3, inhibition constant: 230 nM
Beside the measured number, compound 3's estimate is 9.6-fold (0.98 log units) above it; the whole stated range lies above it.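

Until now the benzoyl ring of the amide had not been varied, and in this assay it proves to be a sensitive part of the molecule: cyano in place of hydrogen on an aromatic carbon gives an 11-fold lower number from compound 1 to compound 3 (1.05 log units; beyond the scatter) and so a clearly stronger inhibitor. Going by these compounds alone, the only earlier step concerned the aromatic ring on an aromatic nitrogen and led to a weaker inhibitor, whereas this one leads to a stronger inhibitor with a group of only 2 heavy atoms. Nothing shown here explains why this change has so large an effect.

The compounds shown leave open whether the gain is specific to the cyano group or would also come with another group on this ring, such as a methoxy group, a chlorine atom or a carboxylic acid, and whether the same group would act alike elsewhere on the ring. Within the data shown here, it also remains open whether the cyano group would give a similar step with pyridin-2-yl in place of 2-bromophenyl, a combination that no compound here carries.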